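The source may hold more compounds than are shown below. What is called first, only, known or untested is meant among the compounds shown, and "the series" means these compounds.

Among the compounds with values here, compound 3 `C#CCCOC(=O)c1ccc(C(CC)(CC)c2ccc(OCC(=O)C(C)(C)C)c(C)c2)n1CC` stands highest of the three numbers so far in an assay on HL-60 cells for agonist activity at vitamin D3 receptor (Homo sapiens), read by microscopy, with a stated time of 96 h; a higher number here means that more compound is needed for the effect, a lower number that less compound is needed: compound 3 gives 28800 nM. Compound 1 `CCn1c(C(=O)NCC(OC)OC)ccc1C(CC)(CC)c1ccc(OCC(=O)C(C)(C)C)c(C)c1` gives 130 nM, and compound 2 `CCn1c(C(=O)N(C)CCC#N)ccc1C(CC)(CC)c1ccc(OCC(=O)C(C)(C)C)c(C)c1` gives 9800 nM. The measured steps run a 75-fold higher number from compound 1 to compound 2 (1.88 log units; beyond the scatter), a 220-fold higher number from compound 1 to compound 3 (2.35 log units; beyond the scatter) and a 2.9-fold higher number from compound 2 to compound 3 (0.47 log units; beyond the scatter); each of them swaps the whole group on the carbonyl carbon, so none of them varies anything within the (but-3-yn-1-yl)oxy group that compound 3 carries.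

Compound 4 `CCn1c(C(=O)OCc2ccccn2)ccc1C(CC)(CC)c1ccc(OCC(=O)C(C)(C)C)c(C)c1` differs from compound 3 in one place: pyridin-2-yl in place of propargyl on a saturated chain carbon bound to an oxygen next to a carbonyl group. Within the data shown here, no measured pair alters a group at that place, so the three steps give no direct guide to this change, and the carbonyl with its oxygen is kept as in compound 3. With nothing in the series pointing either way, the expected step is one within the scatter, a 1.4-fold lower number from compound 3 to compound 4 (0.16 log units; within the scatter), and a wide range is carried. Compound 4 is estimated at 20000 nM, with a range from 6000 nM to 70000 nM.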

Compound 4, half-maximal effective concentration: > 50000 nM
Compound 4 ended at the assay's limit (the forecaster's own chance of this, stated with the estimate: 10%); at least 2.5-fold (0.39 log units) between middle value and limit.
By their numbers in this assay, from the lowest: compound 1; then compound 2; then compound 3. At a limit, above all of these: compound 4.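

In this assay compound 4 reads as a limit of the assay and not as a number: the limit of > 50000 nM in this assay, at which 1 of the 4 values shown sits. At the saturated chain carbon bound to an oxygen next to a carbonyl group, pyridin-2-yl in place of propargyl gives an at least 1.7-fold higher number from compound 3 to compound 4 (0.23 log units; that floor lies within the scatter), so this change brings no measurable lowering of the number, and its real size remains unresolved. Changing the whole group on the carbonyl carbon gives an at least 5.1-fold higher number from compound 2 to compound 4 (0.70 log units; beyond the scatter) and an at least 380-fold higher number from compound 1 to compound 4 (2.58 log units; beyond the scatter), which places (pyridin-2-yl)methoxy, like (but-3-yn-1-yl)oxy, far from the (2,2-dimethoxyethyl)amino of compound 1.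

From the compounds shown here alone, whether pyridin-2-yl is truly worse than propargyl at this place stays open, since only a floor is available. Also open, going by these compounds, is how a phenyl ring at this place, or a (pyridin-2-yl)methylamino group on the carbonyl carbon, would read.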